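The source may report more compounds than this note shows. Statements on the series, on what has been measured and on what is new or still open speak of the compounds shown alone.

Measured compounds:
- Compound 1, `COc1cc(-c2nn(-c3cccc(NC(=O)Nc4cc(C(F)(F)F)cc(C(F)(F)F)c4)c3)cc2-c2ccncc2)ccc1Cl`, gives 1360 nM.
- Compound 2, `COc1cc(-c2nn(-c3cccc(NC(=O)c4cccc(C(F)(F)F)c4)c3)cc2-c2ccncc2)ccc1Cl`, gives 2470 nM.
- Compound 3, `O=C(Nc1cccc(-n2cc(-c3ccncc3)c(-c3ccc(Cl)c(O)c3)n2)c1)Nc1cc(C(F)(F)F)cc(C(F)(F)F)c1`, gives 1250 nM.

All three were tested in a functional assay on SK-MEL-5 cells (Homo sapiens) for inhibition, read by sulforhodamine B assay, with a stated time of 48 h; a higher number here means a weaker inhibitor of growth, a lower number a stronger inhibitor of growth. Compound 2 has the highest of the three numbers, but its gap to compound 1 and its gap to compound 3 both lie within the scatter, so the three cannot be ranked. Among the measured compounds shown here, the one step with a single change, a 1.1-fold lower number from compound 1 to compound 3 (0.04 log units; within the scatter), is also within the scatter.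

Compound 4, `COc1cc(-c2nn(-c3cccc(NC(=O)Nc4ccc(Cl)c(C(F)(F)F)c4)c3)cc2-c2ccncc2)ccc1Cl`, differs from compound 2 by (4-chloro-3-(trifluoromethyl)phenyl)amino in place of 3-(trifluoromethyl)phenyl on a carbonyl carbon. With this change the carbonyl of compound 4 carries the same kind of linkage as in compound 1 and compound 3, which both give numbers within the scatter of compound 2. For the measured compounds named here, no measured step touches this exact exchange, and the one measured step was flat. For compound 4 the expected step from compound 2 is therefore a 1.6-fold lower number from compound 2 to compound 4 (0.22 log units; within the scatter), which is no change beyond the scatter. Compound 4 is estimated at 1500 nM, within a range of 600 nM to 3500 nM.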

Compound 4, concentration for total growth inhibition: 2890 nM
Estimate against measurement, compound 4: 1.9-fold (0.28 log units) below, and the stated range covers the measured number.
By their numbers in this assay, from the lowest: compounds 3, 1, 2 and 4 (each within the scatter of the next, the first and the last beyond it).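

In this assay, putting (4-chloro-3-(trifluoromethyl)phenyl)amino in place of 3-(trifluoromethyl)phenyl on a carbonyl carbon gives a 1.2-fold higher number from compound 2 to compound 4 (0.07 log units; within the scatter), so no change beyond the scatter can be read. Among the compounds shown here, this is the first single-change step at this carbonyl carbon; the earlier step, hydrogen in place of methyl on an oxygen, said nothing about this place. Here the entering group brings a nitrogen, a chlorine and a hydrogen-bond donor in one exchange, and together they leave the number within the scatter, while no measurement at hand explains this flat result.

On these data alone, what the nitrogen link alone does, and what the chlorine alone does, stays open. Also open, as far as these compounds go, is whether a carboxylic acid or a longer alkyl chain in place of the trifluoromethyl would move the number beyond the scatter.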